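The compounds below may be only part of what the source reports. "The series", "measured", "known", "first", "only" and "open" are said of these compounds alone.

Compound 1 `COc1ccc(-c2c(S(=O)(=O)c3ccc(C)c(C)c3)cnc3cc(F)ccc23)cc1` and compound 2 `Cc1ccc(S(=O)(=O)c2cnc3cc(F)ccc3c2-c2cccc(Cl)c2)cc1C` share one core. In an ADME assay on microsomes from liver (Homo sapiens) for metabolic stability, tested at 2.5 uM (on this read-out higher numbers stand for fast clearance and lower numbers for slow clearance), compound 1 gives 4.13 mL/min, and compound 2 gives 4.01 mL/min. The change between them, (3-chlorophenyl in place of 4-methoxyphenyl on an aromatic carbon), made a step of a 1.0-fold lower number from compound 1 to compound 2 (0.01 log units; within the scatter). Compound 3 `COc1ccc(-c2c(S(=O)(=O)c3ccc(F)cc3)cnc3c(F)cccc23)cc1` is built on a different core, and the difference between the two cores is not broken down here; in this assay compound 3 gives 2.41 mL/min. Compound 4 `O=S(=O)(c1ccc(F)cc1)c1cnc2c(F)cccc2c1-c1cccc(Cl)c1` has not yet been measured. It differs from compound 3 by 3-chlorophenyl in place of 4-methoxyphenyl on an aromatic carbon, the same change in the same surroundings as that seen between compound 1 and compound 2. That earlier step stayed within the scatter. On that basis, a step of a 1.0-fold lower number from compound 3 to compound 4 (0.00 log units; within the scatter) in this assay is expected. Compound 4 is therefore estimated at 2.4 mL/min, likely falling between 1.2 mL/min and 4.8 mL/min.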

Compound 4, intrinsic clearance in a liver preparation (reported as CLH), per the amount of preparation that the assay uses: 1.21 mL/min
For compound 4 the middle estimate is 2.0-fold (0.30 log units) above the measured one, and the stated range covers the measured number.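

In this assay, placing 3-chlorophenyl in place of 4-methoxyphenyl gave a 2.0-fold lower number from compound 3 to compound 4 (0.30 log units; within the scatter), and the two cores can be compared directly: the same change on two cores in this assay, a 1.0-fold lower number (0.01 log units; within the scatter) from compound 1 to compound 2 and a 2.0-fold lower number (0.30 log units; within the scatter) from compound 3 to compound 4, 1.9-fold (0.29 log units) apart, within the scatter of two such steps. The change therefore carried from the core of compound 1 to the core of compound 3 with no difference that can be told apart from the scatter, and neither step on its own stands beyond it. This does not show that the two cores respond identically, since two small steps within the scatter could hide a modest difference, and it gives no reason for either step.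

The compounds shown leave open how an amine or a carboxylic acid on that aromatic carbon would read in this assay. They also leave open whether the change would behave the same way on any further core.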